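The source may report more compounds than this note shows. Statements on the series, on what has been measured and on what is new or still open speak of the compounds shown alone.

Within the data shown here, compound 1 `CC(C)(C)c1ccc(/C=C/C(=O)c2ccc(OCC(=O)N[C@H]3CCOC3=O)cc2)cc1` in a functional assay on MGC-803 cells (Homo sapiens) for antiproliferative activity, read by MTT assay, with a stated time of 72 h (on this read-out lower numbers stand for stronger inhibition and higher numbers for weaker inhibition), gives 17200 nM, the only number among the three values shown for the series. Compound 2 `CCCCCCCCCCSC(=S)N[C@H]1CCOC1=O` gives only a limit, > 64000 nM. Compound 3 `O=C(CNc1ccc(F)cc1)N[C@H]1CCOC1=O` likewise gives only a limit, > 64000 nM. Among the measured compounds shown here, compound 1 therefore stands alone as the one measured number, against the limit of > 64000 nM in this assay, at which 2 of the 3 values shown sit, where the other two sit. Compound 4 `O=C(COc1ccc(C(=O)/C=C/c2cccc(F)c2)cc1)N[C@H]1CCOC1=O` differs from compound 1 in one place: 3-fluorophenyl in place of 4-(tert-butyl)phenyl on a double-bonded chain carbon bound to a double-bonded chain carbon. No step between measured compounds is shown, so this change has no precedent within the series in this assay. A step from compound 1 to compound 4 of modest size toward weaker inhibition is expected, a 1.5-fold higher number from compound 1 to compound 4 (0.18 log units; within the scatter). Compound 4 is estimated at 26000 nM, with a range from 8000 nM to 64000 nM.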

Compound 4, half-maximal inhibitory concentration: > 64000 nM
Compound 4: a limit, no number; the forecaster's own chance of this, stated with the estimate: 30%; middle value at least 2.4-fold (0.39 log units) away from the limit.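

In this assay compound 4 gives > 64000 nM, which is a limit and not a number. Among these compounds, at this position, on a double-bonded chain carbon bound to a double-bonded chain carbon, 3-fluorophenyl in place of 4-(tert-butyl)phenyl gives an at least 3.7-fold higher number from compound 1 to compound 4 (0.57 log units; beyond the scatter), the first step that can be read and one that shows the position is sensitive to this change. Compound 4 thereby joins the other limit values: the limit of > 64000 nM in this assay, at which 3 of the 4 values shown sit.

As far as these compounds go, the full size of the step remains open, as does whether the loss of the tert-butyl group or the entry of fluorine drives it. An unsubstituted phenyl or a chlorophenyl group at this position would help to separate the two.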